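A few compounds are considered here, and "the series" means these few. Any claim that something is new, unique, unknown or untested is made for them only; others in the source may bear on it.

Measured in a functional assay on cells (Platelet, Homo sapiens) for inhibition; on this read-out lower numbers stand for stronger inhibition and higher numbers for weaker inhibition:
- Compound 1 `CCOC(=O)c1ccc(-c2nn(Cc3cccc(F)c3)c3ccccc23)cc1`: > 10000 nM (a limit)
- Compound 2 `CCOC(=O)c1ccc(-c2nn(Cc3cccc(OC)c3)c3ccccc23)cc1`: > 10000 nM (a limit)
- Compound 3 `CCOC(=O)c1ccc(-c2nn(Cc3ccncc3)c3ccccc23)cc1`: > 10000 nM (a limit)

Compound 3 gives > 10000 nM, which is a limit of this assay and not a number. It shares this position with its two relatives, and the whole set so far is summed up as the limit of > 10000 nM in this assay, at which 3 of the 3 values shown sit.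

Compound 4 `CCOC(=O)c1ccc(-c2nn(CC)c3ccccc23)cc1` keeps the core of compound 3 and changes one group: methyl in place of pyridin-4-yl on a saturated chain carbon bound to an aromatic nitrogen. In words, this is methyl in place of pyridin-4-yl on a saturated chain carbon bound to an aromatic nitrogen, so (pyridin-4-yl)methyl becomes ethyl.

For the measured compounds named here, two measured steps touch this same place: a step that the two limits leave unreadable from compound 1 to compound 3 and a step that the two limits leave unreadable from compound 2 to compound 3. A third, a step that the two limits leave unreadable from compound 1 to compound 2, alters a group further along that side of the molecule. None of these steps has a readable size, so they give no direction for the new change. Going by the values given here, none of the three ring groups tested here produced a number, and no compound measured so far lacks a ring at this place. The most likely result is therefore another limit, and no definite gain or loss is expected. The expected change is a step that the limit leaves unreadable from compound 3 to compound 4.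

For compound 4, the estimated value is 20000 nM, with an expected range from 6000 nM to 60000 nM.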

Compound 4, half-maximal inhibitory concentration: > 10000 nM
Compound 4: a limit, no number (the forecaster's own chance of this, stated with the estimate: 90%); the middle value is on the limit's open side.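

In this assay compound 4 gives > 10000 nM, which is a limit and not a number. The steps from compound 1, compound 2 and compound 3 to compound 4 cannot be read, and the whole set stands at one value: the limit of > 10000 nM in this assay, at which 4 of the 4 values shown sit. The compounds shown leave open which change, if any, would give a measurable inhibition value.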